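From methoxy to ethoxy on compound 1

A few compounds are considered here, and "the series" means these few. Any claim that something is new, unique, unknown or untested is made for them only; others in the source may bear on it.

Measured in a functional assay on K562 cells (Homo sapiens) for antiproliferative activity, read by MTT assay, with a stated time of 72 h; on this read-out higher numbers stand for weaker inhibition and lower numbers for stronger inhibition:
Compound 1 `COc1ccc(-c2ncnn2-c2cc(OC)c(OC)c(OC)c2)cc1`: 950 nM
Compound 2 `COc1cc(-n2ncnc2-c2ccc(Cl)c(Cl)c2)cc(OC)c1OC`: > 10000 nM (a limit of the assay)

Among the measured compounds shown here, compound 1, with 950 nM, holds the only true number in this small set. Compound 2 reports > 10000 nM, which is a limit and not a number.

Compound 3 `CCOc1ccc(-c2ncnn2-c2cc(OC)c(OC)c(OC)c2)cc1` keeps the core of compound 1 and carries one change: methyl in place of hydrogen on a saturated chain carbon bound to an oxygen on an aromatic ring. This is methyl in place of hydrogen on a saturated chain carbon bound to an oxygen on an aromatic ring, so methoxy becomes ethoxy.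

For the measured compounds named here, only one measured step bears on this change. It is an at least 10-fold higher number from compound 1 to compound 2 (1.02 log units; beyond the scatter), a large step beyond the scatter, in which 3,4-dichlorophenyl replaces 4-methoxyphenyl. That step shows that this assay can respond strongly to a change in this part of compound 1. However, it replaces the whole group, while compound 3 keeps the 4-position oxygen substituent and only extends it. A much smaller move towards a higher number is therefore expected.

The expected step is a 1.6-fold higher number from compound 1 to compound 3 (0.20 log units; within the scatter).

For compound 3 the estimated value is 1500 nM, with an expected range from 400 nM to 6000 nM.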

Compound 3, half-maximal inhibitory concentration: 20 nM
Compound 3: the middle estimate sits 75-fold (1.88 log units) above what was measured; measured number outside the range, below it.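

In this assay, lengthening methoxy to ethoxy gives a 48-fold lower number from compound 1 to compound 3 (1.68 log units; beyond the scatter), which shows that this position responds strongly to a change of a single methyl, on a saturated chain carbon bound to an oxygen on an aromatic ring. The earlier pair showed only that replacing the whole 4-methoxyphenyl group with 3,4-dichlorophenyl moves the number upwards, whereas compound 3 shows that the same part of the molecule can also move it far downwards while the oxygen stays in place and the shared core is untouched. Compound 2 remains a limit and not a number, so the only true numbers for this comparison come from compound 1 and compound 3: the limit of > 10000 nM in this assay, at which 1 of the 3 values shown sits.

From the compounds shown here alone, what stays open is whether the trend continues with a longer chain such as propoxy, or with a branched isopropoxy group, or whether ethoxy already marks the best length. Going by these compounds, it is also open how a terminal hydroxyl or an amine on that chain would behave, and whether the effect of the methyl would carry over to any read-out other than this one.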